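A few compounds are considered here, and "the series" means these few. Any claim that something is new, unique, unknown or untested is made for them only; others in the source may bear on it.

Measured so far in a functional assay on MCF7 cells (Homo sapiens) for cytotoxicity, read by MTT assay, with a stated time of 72 h; a lower number here means that less compound is tolerated, a higher number that more compound is tolerated:

- compound 1 `COc1ccc(OC(=O)Nc2ccc([Se]C#N)cc2)cc1` — 74100 nM
- compound 2 `CC(C)COC(=O)Nc1ccc([Se]C#N)cc1` — 73000 nM
- compound 3 `O=C(Nc1ccc([Se][Se]c2ccc(NC(=O)OCc3ccc([N+](=O)[O-])cc3)cc2)cc1)OCc1ccc([N+](=O)[O-])cc1` — 85000 nM

The three numbers in this assay sit close together. Compound 1 lies between the other two, and its distance to compound 2 as well as its distance to compound 3 falls within the usual scatter of repeated measurements, so no ordering among the three can be read from these values. Among the measured compounds shown here, no two of the measured compounds differ in a single place, so there is no measured step to lean on.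

Compound 4 `N#C[Se]c1ccc(NC(=O)Oc2ccc(Cl)cc2)cc1` is the next candidate. It differs from compound 1 in one place: chloro in place of methoxy on an aromatic carbon. For the measured compounds named here, nothing among the measured compounds shows what such an exchange does in this assay; the carbamate and the selenocyanate part of compound 1 stay as they are. With the values of compound 1, compound 2 and compound 3 all lying within the scatter of one another despite quite different carbamate groups, the expectation for compound 4 is a number close to that of compound 1, with no step beyond the scatter.

Compound 4 is estimated at 75000 nM in this assay, with a range from 35000 nM to 160000 nM. The expected step of a 1.0-fold higher number from compound 1 to compound 4 (0.01 log units; within the scatter) is no more than the scatter; a value outside the measured window would be a surprise.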

Compound 4, concentration lethal to 50% of the cells: 63600 nM
Compound 4: the middle estimate sits 1.2-fold (0.07 log units) above what was measured; measured number inside the range.
By their numbers in this assay, from the lowest: compounds 4, 2, 1 and 3 (each within the scatter of the next).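

In this assay, among the compounds shown here, chloro in place of methoxy on an aromatic carbon, para to a large group, provides the first single-place step: a 1.2-fold lower number from compound 1 to compound 4 (0.07 log units; within the scatter). At this position, then, the exchange leaves no difference that can be told from the scatter, even though the methoxy oxygen and its hydrogen-bond acceptor are gone and the carbamate and the selenocyanate stay as they are; this holds for this one pair and says nothing yet about other groups at this position. No measured evidence is available to explain the result.

Going by these compounds, it remains open whether this position would stay equally flat with an amine, a carboxylic acid or a longer chain such as butoxy in place of the methoxy of compound 1. Also open, on these data alone, is what a hydrogen in place of the selenocyanate on the core of compound 1 would do to the number, so the contribution of that group cannot yet be read from any single-place step.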